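Amino for methylsulfanyl on a weakly active nucleoside core

The source may report more compounds than this note shows. Statements on the series, on what has been measured and on what is new or still open speak of the compounds shown alone.

Compound 1, `CNc1nc(SC)nc2c1ncn2[C@@H]1C[C@@H](O)[C@H](CO)O1`, > 300 uM (a limit)
Compound 2, `CSc1nc(SC)c2ncn([C@@H]3C[C@@H](O)[C@H](CO)O3)c2n1`, > 300 uM (a limit)
Compound 3, `CNc1nc(Br)nc2c1ncn2[C@@H]1C[C@@H](O)[C@H](CO)O1`, 143 uM

In a functional assay on HL-60 cells (Homo sapiens) (a higher number here means a weaker inhibitor, a lower number a stronger inhibitor), compound 2 gives only a limit, > 300 uM. Compound 1 likewise gives only a limit, sitting at the limit of > 300 uM in this assay, at which 2 of the 3 values shown sit. Compound 3 gives a number, 143 uM. The step that the two limits leave unreadable from compound 1 to compound 2 is therefore unreadable, whereas an at least 2.0-fold lower number from compound 1 to compound 3 (0.32 log units; beyond the scatter) is at least modest. Compound 4 `CSc1nc(N)c2ncn([C@@H]3C[C@@H](O)[C@H](CO)O3)c2n1` differs from compound 2 by amino in place of methylsulfanyl on an aromatic carbon. Among the measured compounds shown here, no measured step covers this change, and the two values for compounds 1 and 2 show that a methylamino and a methylsulfanyl at this position both sit at the limit. Compound 4 is therefore expected to remain weak, with a number no higher from compound 2 to compound 4 (the limit leaves the size open) likely small, and an estimated value of 300 uM, between 100 uM and 1000 uM.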

Compound 4, concentration for 50% inhibition: > 300 uM
Compound 4: a limit, no number (the forecaster's own chance of this, stated with the estimate: 65%); the middle value lies on the limit itself.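

In this assay compound 4 gives only a limit, > 300 uM, so its steps from compound 1 and compound 2 cannot be read. The compounds shown leave open whether amino, methylamino and methylsulfanyl differ at all in this assay.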